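Swapping Dimethoxyphenyl for Dihydroxyphenyl on a Hydrazone Urea

The source may hold more compounds than are shown below. What is called first, only, known or untested is meant among the compounds shown, and "the series" means these compounds.

Of the compounds shown here, three built on one shared core have been measured in a functional assay on A549 cells (Homo sapiens) for cytotoxicity, read by MTT assay, with a stated time of 72 h; a higher number here means a weaker inhibitor, a lower number a stronger inhibitor. Compound 1 `COc1ccc(/C=N/NC(=O)Nc2ccc(Oc3ccnc(-c4nncn4CCN(C)C)c3)c(F)c2)c(OC)c1` gives 2820 nM. Compound 2 `COc1ccc(/C=N/NC(=O)Nc2ccc(Oc3ccnc(-c4nncn4CCN(C)C)c3)c(F)c2)c(OC)c1OC` gives 6680 nM, and compound 3 `CN(C)CCn1cnnc1-c1cc(Oc2ccc(NC(=O)N/N=C/c3ccccc3)cc2F)ccn1` gives 1860 nM. Compound 1 therefore stands second highest of the three numbers: its nearest neighbour is compound 3, reached by a 1.5-fold lower number from compound 1 to compound 3 (0.18 log units; within the scatter), and its furthest is compound 2, reached by a 2.4-fold higher number from compound 1 to compound 2 (0.37 log units; beyond the scatter).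

Compound 4 `CN(C)CCn1cnnc1-c1cc(Oc2ccc(NC(=O)N/N=C/c3ccc(O)c(O)c3)cc2F)ccn1` has not yet been measured. It differs from compound 1 in a single place: 3,4-dihydroxyphenyl in place of 2,4-dimethoxyphenyl on a carbon with a double bond to nitrogen. Among the compounds with values here, no measured step makes this exact exchange, so the guide is the behaviour of the same ring under other changes. Stripping the ring down to plain phenyl gave a 1.5-fold lower number from compound 1 to compound 3 (0.18 log units; within the scatter), a small step, and stripping it from three methoxy groups gave a 3.6-fold lower number from compound 2 to compound 3 (0.56 log units; beyond the scatter), a modest step down. Fewer methoxy groups thus went with lower or unchanged numbers, while hydroxy groups on this ring have no precedent among the measured compounds. Compound 4 is therefore expected to give 2500 nM, with a range from 800 nM to 8000 nM. The expected step, a 1.1-fold lower number from compound 1 to compound 4 (0.05 log units; within the scatter), is estimated to lie within the scatter.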

Compound 4, half-maximal inhibitory concentration: > 100000 nM
Compound 4: no number, only a limit; the forecaster's own chance of this, stated with the estimate: 5%; middle value at least 40-fold (1.60 log units) away from the limit.
By their numbers in this assay, from the lowest: compounds 3 and 1 (each within the scatter of the next); then compound 2. At a limit, above all of these: compound 4.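

Compound 4 gives a limit of the assay, not a number: the limit of > 100000 nM in this assay, at which 1 of the 4 values shown sits.

Among the earlier compounds, changes to this ring on the carbon with a double bond to nitrogen produced modest steps at most, whereas this exchange produces large ones: an at least 35-fold higher number from compound 1 to compound 4 (1.54 log units; beyond the scatter), an at least 53-fold higher number from compound 3 to compound 4 (1.73 log units; beyond the scatter) and an at least 14-fold higher number from compound 2 to compound 4 (1.17 log units; beyond the scatter). The position therefore does not accept every group alike, since the plain phenyl of compound 3 and the methoxy-bearing rings of compound 1 and compound 2 all give numbers in this assay, while the 3,4-dihydroxyphenyl of compound 4, with 2 hydrogen-bond donors where 2,4-dimethoxyphenyl has 0, gives none.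

The compounds shown do not separate the effect of having hydroxy groups at all from the effect of where they stand on the ring, and they offer no explanation for the large steps. A ring with a single hydroxy group, one with methoxy groups in the places of the two hydroxy groups of compound 4, or one carrying an amine or a carboxylic acid would each test a different part of this open question.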